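This account rests on a few compounds, and the source may have more. Where it says the series, first, only, none or still open, it means among the compounds named here.

Compound 1 `CSCC[C@H](NC1=CC(=O)C=C(C[C@]2(C)[C@@H](C)CC[C@]3(C)C(C)=CCC[C@@H]23)C1=O)C(=O)O`: 25600 nM
Compound 2 `CC1=CCC[C@H]2[C@](C)(CC3=CC(=O)C=C(N[C@@H](C(=O)O)C(C)C)C3=O)[C@@H](C)CC[C@]12C`: 8010 nM

In a functional assay on MDA-MB-453 cells (Homo sapiens) for cytotoxicity, read by MTT assay, with a stated time of 72 h (on this read-out lower numbers stand for stronger inhibition and higher numbers for weaker inhibition), compound 2 holds the lower of the two numbers, at 8010 nM. Compound 3 `CC1=CCC[C@H]2[C@](C)(CC3=CC(=O)C=C(N[C@@H](C)C(=O)O)C3=O)[C@@H](C)CC[C@]12C` differs from it in one group: 1-carboxyethyl in place of 1-carboxy-2-methylpropyl on an amine nitrogen. In words, 1-carboxyethyl stands in place of 1-carboxy-2-methylpropyl on an amine nitrogen. Going by the values given here, only one measured step changes this same place: a 3.2-fold lower number from compound 1 to compound 2 (0.50 log units; beyond the scatter). That single modest step sets no firm trend, so only a small change is expected, with its direction uncertain. The expected change in this assay is a 1.2-fold higher number from compound 2 to compound 3 (0.10 log units; within the scatter), probably within the scatter. For compound 3 the estimate is 10000 nM, with an expected range of 4000 nM to 25000 nM.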

Compound 3, half-maximal inhibitory concentration: 14700 nM
Compound 3: the middle estimate sits 1.5-fold (0.17 log units) below what was measured, within the range that was stated.
By their numbers in this assay, from the lowest: compounds 2, 3 and 1 (each within the scatter of the next, the first and the last beyond it).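

In this assay, the change to 1-carboxyethyl gives a 1.8-fold higher number from compound 2 to compound 3 (0.26 log units; within the scatter) and hydrogen in place of (methylsulfanyl)methyl gives a 1.7-fold lower number from compound 1 to compound 3 (0.24 log units; within the scatter) as the second step. Compound 3 therefore cannot be ranked against either compound 1 or compound 2, although those two stand apart, so the three side chains on this amine nitrogen span only a modest range. Nothing available explains these numbers. As far as these compounds go, whether a benzyl side chain, or an amide in place of the carboxylic acid, would move the number further remains open.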